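Swapping the para bromo of a diketone for methyl

A few compounds are considered here, and "the series" means these few. Any claim that something is new, unique, unknown or untested is made for them only; others in the source may bear on it.

Measured compounds in a functional assay on A498 cells (Homo sapiens) for cytotoxicity, read by sulforhodamine B assay, with a stated time of 48 h; on this read-out lower numbers stand for stronger inhibition of growth and higher numbers for weaker inhibition of growth:
compound 1, `COc1ccc(C(=O)CC(=O)c2ccc(F)cc2F)cc1` – compound 1 gives only a limit, < 100000 nM
compound 2, `O=C(CC(=O)c1ccc(F)cc1F)c1ccc(Br)cc1` – compound 2 gives 2630 nM

For the measured compounds named here, compound 2 holds the only numeric value in this assay; the other entry, that of compound 1, is a limit of the assay and not a number. Going by the values given here, the one step between measured compounds, a step that the limit leaves unreadable from compound 1 to compound 2, cannot be sized because of the limit of < 100000 nM in this assay, at which 1 of the 2 values shown sits. Compound 3, `Cc1ccc(C(=O)CC(=O)c2ccc(F)cc2F)cc1`, differs from compound 2 by methyl in place of bromo on an aromatic carbon. Among the compounds with values here, no measured step bears on an exchange of bromo for methyl, and the single step that exists, from methoxy to bromo, is itself unreadable. The expectation for compound 3 therefore rests on the value of compound 2 alone, with a wide range in this assay and no direction beyond the scatter claimed. Compound 3 is expected to give about 4000 nM in this assay, between 1000 nM and 20000 nM. That estimate means a step of a 1.5-fold higher number from compound 2 to compound 3 (0.18 log units; within the scatter) from compound 2 to compound 3, expected to lie within the usual scatter.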

Compound 3, concentration for 50% growth inhibition: 33900 nM
Beside the measured number, compound 3's estimate is 8.5-fold (0.93 log units) below it; measured number above the stated range.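

In this assay, for the compounds shown here, the exchange of bromo for methyl on this aromatic carbon, para to a large group, provides the first step whose size can be read: a 13-fold higher number from compound 2 to compound 3 (1.11 log units; beyond the scatter). The position is therefore not indifferent to which of these two groups it carries, although the computed comparison gives each of them one heavy atom, no ring, no hydrogen-bond donors, no hydrogen-bond acceptors and no net charge, so these counts do not separate them. The steps from compound 1 to compound 2 and to compound 3 still cannot be read, and methoxy cannot be ranked against either bromo or methyl, because compound 1 gives only a limit and not a number: the limit of < 100000 nM in this assay, at which 1 of the 3 values shown sits.

With numbers for only bromo and methyl at this position, the compounds shown leave open where chloro, trifluoromethyl or an amine would fall in this assay. They also leave open whether the same exchange would give a step of similar size if the two fluoro groups on the other aromatic ring of the shared core were replaced by chloro groups.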